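This account rests on a few compounds, and the source may have more. Where it says the series, first, only, none or still open, it means among the compounds named here.

Measured in a functional assay on HL-60 cells (Homo sapiens) for cytotoxicity, read by MTT assay, with a stated time of 96 h; a lower number here means a stronger inhibitor, a higher number a weaker inhibitor:
- compound 1 `CC[C@H](NC)C(=O)N[C@@H]1C(=O)N2[C@@H](CC[C@@H]1CN)CC[C@H]2C(=O)NC(c1ccccc1)c1ccccc1`: 51800 nM
- compound 2 `CC[C@H](N)C(=O)N[C@@H]1C(=O)N2[C@@H](CC[C@@H]1CCN)CC[C@H]2C(=O)NC(c1ccccc1)c1ccccc1`: 25000 nM
- compound 3 `CCNCC[C@H]1CC[C@H]2CC[C@@H](C(=O)NC(c3ccccc3)c3ccccc3)N2C(=O)[C@H]1NC(=O)[C@H](CC)NC`: 76400 nM

Compound 2, at 25000 nM, has the lowest of the three numbers, and the gaps to compound 1 and compound 3 both lie beyond the scatter. All three values are high.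

Next in line is compound 4 `CC[C@H](N)C(=O)N[C@@H]1C(=O)N2[C@@H](CC[C@@H]1CCNCc1ccccc1)CC[C@H]2C(=O)NC(c1ccccc1)c1ccccc1`, which carries benzyl in place of hydrogen on an amine nitrogen, turning 2-aminoethyl into 2-(benzylamino)ethyl: benzyl in place of hydrogen on an amine nitrogen.

Going by the values given here, one measured step bears on this change: a 1.5-fold higher number from compound 1 to compound 3 (0.17 log units; within the scatter). There, (ethylamino)methyl replaces amino, and the step stays within the scatter. Among the compounds with values here, it is only a loose guide, since no compound yet carries a benzyl group.

No shift beyond the scatter is therefore expected in this assay. The expected step is a 1.1-fold lower number from compound 2 to compound 4 (0.06 log units; within the scatter). The estimate for compound 4 is 22000 nM, with an expected range of 8000 nM to 70000 nM.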

Compound 4, half-maximal inhibitory concentration: 15400 nM
Estimate against measurement, compound 4: 1.4-fold (0.15 log units) above; the range from low to high includes it.
By their numbers in this assay, from the lowest: compounds 4 and 2 (each within the scatter of the next); then compounds 1 and 3 (each within the scatter of the next).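

In this assay, benzyl in place of hydrogen on the amine nitrogen of the 2-aminoethyl chain gives a 1.6-fold lower number from compound 2 to compound 4 (0.21 log units; within the scatter), so this nitrogen carries a substituent with a six-membered aromatic ring without a shift beyond the scatter. Going by these compounds alone, until now, the only substituted amine step was (ethylamino)methyl in place of amino, with a 1.5-fold higher number from compound 1 to compound 3 (0.17 log units; within the scatter), and it involved no aromatic ring. Nothing available explains either step.

Still open, on these data alone, is whether a longer link to the ring, as in 2-phenylethyl, or a carboxylic acid on the benzyl ring would move the number beyond the scatter. As far as these compounds go, it is also open whether benzyl on the aminomethyl chain of compound 1 would give a step like the one on the 2-aminoethyl chain.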